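Swapping 4-methylphenyl for 2-nitrophenyl: an expected outcome

The source may report more compounds than this note shows. Statements on the series, on what has been measured and on what is new or still open speak of the compounds shown alone.

Compound 1 `O=C(CCCCCNC(=S)NN=C(c1ccccc1)c1ccccc1)NO` gives 3810 nM
Compound 2 `Cc1ccc(/C(=N/NC(=S)NCCCCCC(=O)NO)c2ccccc2)cc1` gives 4340 nM

In a functional assay on K562 cells (Homo sapiens) for antiproliferative activity, read by MTT assay (on this read-out higher numbers stand for weaker inhibition and lower numbers for stronger inhibition), compound 2 stands level with compound 1, the two values lying within the scatter of each other. Compound 3 `O=C(CCCCCNC(=S)N/N=C(\c1ccccc1)c1ccccc1[N+](=O)[O-])NO` has not been measured. It carries 2-nitrophenyl in place of 4-methylphenyl on a carbon with a double bond to nitrogen. Going by the values given here, one measured step bears on this, a 1.1-fold higher number from compound 1 to compound 2 (0.06 log units; within the scatter) for methyl in place of hydrogen on an aromatic carbon. Among the compounds with values here, that step is small, but the change behind it is a smaller one, and no measured compound carries 2-nitrophenyl. No step beyond the scatter is therefore expected in this assay here, with a wide margin either way. The estimated step is a 1.1-fold lower number from compound 2 to compound 3 (0.04 log units; within the scatter) and it carries that margin. Compound 3 is expected to give 4000 nM in an estimated range of 1500 nM to 11000 nM when tested.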

Compound 3, half-maximal inhibitory concentration: 2330 nM
Compound 3: middle estimate off by 1.7-fold (0.23 log units), on the high side; the measured number falls inside the stated range.
By their numbers in this assay, from the lowest: compounds 3, 1 and 2 (each within the scatter of the next).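

Putting 2-nitrophenyl on the carbon with a double bond to nitrogen gives a 1.9-fold lower number from compound 2 to compound 3 (0.27 log units; within the scatter) in this assay, and adding nitro alone gives a 1.6-fold lower number from compound 1 to compound 3 (0.21 log units; within the scatter). Together with the earlier methyl step, this shows that a change larger than adding methyl, one that brings in 2 hydrogen-bond acceptors and 9 heavy atoms in place of 7, still leaves all three compounds within the scatter of one another. No measurement at hand speaks to what lies behind these numbers.

Still open, from the compounds shown here alone, is whether an amine or a carboxylic acid on this aromatic ring would give a step beyond the scatter. Also open, going by these compounds, is whether a longer chain in the shared core would do so.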